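Bromo for nitro on two fused bicyclic cores

A few compounds are considered here, and "the series" means these few. Any claim that something is new, unique, unknown or untested is made for them only; others in the source may bear on it.

Compound 1 `CC1(COc2ccc(OC(F)(F)F)cc2)Cn2cc([N+](=O)[O-])nc2O1` and compound 2 `CC1(COc2ccc(OC(F)(F)F)cc2)Cn2cc(Br)nc2O1` share one core; compound 3 `CC1(COc2ccc(OC(F)(F)F)cc2)Cn2nc([N+](=O)[O-])nc2O1` and compound 4 `CC1(COc2ccc(OC(F)(F)F)cc2)Cn2nc(Br)nc2O1` share another, and the difference between the two cores is not broken down here. In an ADME assay on MRC5 cells (Homo sapiens) for cytotoxicity, read by fluorescence, with a stated time of 72 h (on this read-out higher numbers stand for weaker inhibition and lower numbers for stronger inhibition), compound 1 gives only a limit, > 64000 nM. Compound 2 gives 34000 nM in this assay. The step of an at least 1.8-fold lower number from compound 1 to compound 2 (0.27 log units; that floor lies within the scatter) is the change (bromo in place of nitro on an aromatic carbon). Compound 3 gives only a limit in this assay, > 64000 nM. The measured step has only a floor because of the limit of > 64000 nM in this assay, at which 2 of the 3 values shown sit. The change bromo in place of nitro on an aromatic carbon is the same kind of change as from compound 1 to compound 2, but not the same: it sits on a five-membered aromatic ring with 3 nitrogen, between two ring nitrogen atoms, whereas the earlier one sits on a ring with 2 nitrogen, next to the ring nitrogen. Compound 4 has not been measured in this assay. The step expected in this assay is an at least 1.6-fold lower number from compound 3 to compound 4 (0.20 log units; that floor lies within the scatter), resting on compound 2 with 34000 nM and on the measured step of an at least 1.8-fold lower number from compound 1 to compound 2 (0.27 log units; that floor lies within the scatter). Compound 4 is expected to give 40000 nM, with a span from 15000 nM to 100000 nM. A limit rather than a number remains plausible for compound 4.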

Compound 4, half-maximal inhibitory concentration: 43000 nM
Beside the measured number, compound 4's estimate is 1.1-fold (0.03 log units) below it; low and high end bracket the measured number.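

Carried to the second core, bromo in place of nitro on an aromatic carbon gives an at least 1.4-fold lower number from compound 3 to compound 4 (0.17 log units; that floor lies within the scatter) in this assay. On both cores the bromo compound gives a number and the nitro compound only a limit, so the change transfers no further than this shared pattern in two pairs, and the two steps can be set side by side only as floors: the same change on two cores in this assay, an at least 1.8-fold lower number (0.27 log units; that floor lies within the scatter) from compound 1 to compound 2 and an at least 1.4-fold lower number (0.17 log units; that floor lies within the scatter) from compound 3 to compound 4; the limit leaves it open whether they differ The true size of neither step can be read, and no agreement in size can be claimed, because both nitro compounds stand at a limit: the limit of > 64000 nM in this assay, at which 2 of the 4 values shown sit.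

The compounds shown leave open whether another group on the same aromatic carbon, such as a nitrile or an amine, would give a number in this assay and how it would compare with bromo. They also leave open whether the pattern would hold if the trifluoromethoxy group gave way to a carboxylic acid or a longer chain.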